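The source may hold more compounds than are shown below. What is called first, only, known or untested is meant among the compounds shown, and "the series" means these compounds.

Among the three compounds measured in an in vitro functional assay on HEK285-7 cells for antagonist activity at prostaglandin D2 receptor 2 (Homo sapiens), read by BRET and beta-arrestin recruitment (a lower number here means a stronger inhibitor, a higher number a weaker inhibitor), compound 3 `O=C(O)Cc1sc(C(c2ccc(F)cc2)c2ccc(F)cc2)nc1-c1cc(F)nc(F)c1` stands lowest, with 110 nM. Compound 2 `NS(=O)(=O)c1cccc(-c2nc(C(c3ccc(F)cc3)c3ccc(F)cc3)sc2CC(=O)O)c1` gives 710 nM, and compound 1 `N#Cc1ccc(-c2nc(C(c3ccc(F)cc3)c3ccc(F)cc3)sc2CC(=O)O)cc1` gives 1500 nM. All three share one core and differ only in the aromatic group carried on it, and changing that group has moved the numbers clearly: a 2.1-fold lower number from compound 1 to compound 2 (0.32 log units; beyond the scatter), a 14-fold lower number from compound 1 to compound 3 (1.13 log units; beyond the scatter), and a 6.5-fold lower number from compound 2 to compound 3 (0.81 log units; beyond the scatter).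

Compound 4 `O=C(O)Cc1sc(C(c2ccc(F)cc2)c2ccc(F)cc2)nc1-c1ccnc(N2CCCC2)c1` changes that same group once more: 2-(pyrrolidin-1-yl)pyridin-4-yl in place of 2,6-difluoropyridin-4-yl on an aromatic carbon. The measured steps show that swapping this group is never a small matter here, but they also show that compound 3 holds the best number of the set, so the next change has more room to go up than down. The step from compound 3 to compound 4 is therefore expected to be a 3.6-fold higher number from compound 3 to compound 4 (0.56 log units; beyond the scatter), a weaker result, though with wide uncertainty. Compound 4 is estimated at 400 nM in this assay, within a range of 100 nM to 1500 nM.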

Compound 4, half-maximal inhibitory concentration: > 100000 nM
Compound 4 gave a limit, no number; the forecaster's own chance of this, stated with the estimate: 5%; middle value at least 250-fold (2.39 log units) from the limit.
By their numbers in this assay, from the lowest: compound 3; then compound 2; then compound 1. At a limit, above all of these: compound 4.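

Compound 4 gave a limit and no number: the limit of > 100000 nM in this assay, at which 1 of the 4 values shown sits.

Set against that limit, all three earlier compounds lie far lower: an at least 900-fold higher number from compound 3 to compound 4 (2.95 log units; beyond the scatter), an at least 140-fold higher number from compound 2 to compound 4 (2.14 log units; beyond the scatter), and an at least 66-fold higher number from compound 1 to compound 4 (1.82 log units; beyond the scatter). The earlier compounds shown here showed this position shifting the number within a measurable span, whereas this change shows that one replacement on this aromatic carbon can carry the result out of that span altogether. Compound 3 and compound 4 both carry a pyridin-4-yl ring, so that ring alone does not preserve activity here, and what differs between them is two fluorines against one pyrrolidin-1-yl group.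

The compounds shown leave open whether a smaller amine such as dimethylamino would stay close to compound 3 or fall towards compound 4. They also leave open how a pyridin-4-yl ring bearing a single fluorine would compare.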